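A few compounds are considered here, and "the series" means these few. Any claim that something is new, unique, unknown or untested is made for them only; others in the source may bear on it.

Compound 1, `ClCc1ccccc1Cn1cnc2c(Cl)nc(Cl)nc21`, is the compound in this set that tolerates the least material in a functional assay on CAKI-1 cells (Homo sapiens) for cytotoxicity, read by sulforhodamine B assay, with a stated time of 48 h; a lower number here means that less compound is tolerated, a higher number that more compound is tolerated. In this assay compound 1 gives 3090 nM. Its nearest neighbour on this read-out is compound 2, `ClCc1cccc(Cn2cnc3c(Cl)nc(Cl)nc32)c1`, which in this assay gives 22900 nM, a higher number, and the gap between the two is beyond the usual scatter. Compound 3, `ClCc1cccc(Cn2cnc3nc(Cl)nc(Cl)c32)c1`, belongs to the same series, but in this assay compound 3 gives "not determined" (no result reported), so no result was reported for it. Compound 4, `Nc1nc(Cl)c2ncn(Cc3ccccc3CCl)c2n1`, has not been measured in this assay. It differs from compound 1 in a single place: amino in place of chloro on an aromatic carbon. For the measured compounds named here, no measured pair in this set reproduces that change, so there is nothing to read a step from directly. Compound 4 is expected to give a somewhat higher number than compound 1 in this assay, and the expected step from compound 1 to compound 4 of a 1.8-fold higher number from compound 1 to compound 4 (0.25 log units; within the scatter) would be modest. Compound 4 is therefore estimated at 5500 nM, within a range of 1500 nM to 20000 nM.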

Compound 4, concentration lethal to 50% of the cells: 50100 nM
Compound 4: middle estimate off by 9.1-fold (0.96 log units), on the low side; the measured number lies above the stated range.
By their numbers in this assay, from the lowest: compound 1; then compound 2; then compound 4.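

Until now every compound in the series carried chloro on this aromatic carbon between two ring nitrogen atoms, so the position itself had not been read. In this assay, amino in place of chloro gives a 16-fold higher number from compound 1 to compound 4 (1.21 log units; beyond the scatter), a large change from swapping a single atom on the core of compound 1, with everything else in the pair left as it was. The pair shows the size and direction of this one change, but nothing given here bears on why the number rises this far.

The compounds shown leave open whether methylamino, dimethylamino or methoxy on the same carbon would move the number as far as amino does. They also leave open whether amino would give a similar step with the chloromethyl group placed as in compound 2.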